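From benzofuranyl to iodo at the assay limit

This account rests on a few compounds, and the source may have more. Where it says the series, first, only, none or still open, it means among the compounds named here.

Measured in a functional assay on A549 cells (Homo sapiens), read by MTT assay, with a stated time of 72 h; on this read-out higher numbers stand for weaker inhibition and lower numbers for stronger inhibition
Compound 1 (`CN(C)c1ncnc2c1c(-c1cc3ccccc3o1)cn2[C@@H]1O[C@H](CO)[C@@H](O)[C@H]1O`) > 20000 nM
Compound 2 (`Cc1ncnc2c1c(-c1ccsc1)cn2[C@@H]1O[C@H](CO)[C@@H](O)[C@H]1O`) > 20000 nM
Compound 3 (`Cc1ncnc2c1c(-c1cc3ccccc3o1)cn2[C@@H]1O[C@H](CO)[C@@H](O)[C@H]1O`) > 20000 nM

All three values are limits of the assay, not numbers. Compound 3 sits at the limit of > 20000 nM in this assay, at which 3 of the 3 values shown sit, and has no number of its own. Compound 4 (`Cc1ncnc2c1c(I)cn2[C@@H]1O[C@H](CO)[C@@H](O)[C@H]1O`) carries iodo in place of 1-benzofuran-2-yl on an aromatic carbon. The measured steps are a step that the two limits leave unreadable from compound 2 to compound 3 and a step that the two limits leave unreadable from compound 1 to compound 3 and neither gives a size or direction. The first changes the same carbon. Going by the values given here, no iodo compound has been measured, so a move toward stronger inhibition in this assay is expected only tentatively, and a result at the limit is about as likely. The expected step is modest (an at least 2.0-fold lower number from compound 3 to compound 4 (0.30 log units; that floor lies within the scatter)). Compound 4 is estimated at 10000 nM (range 1500 nM to 20000 nM).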

Compound 4, half-maximal inhibitory concentration: 12200 nM
For compound 4 the middle estimate is 1.2-fold (0.09 log units) below the measured one; the measured number falls inside the stated range.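

In this assay compound 4 is the only compound shown with a number of its own, so this aromatic carbon, where no earlier step could be read, now gives an at least 1.6-fold lower number from compound 3 to compound 4 (0.21 log units; that floor lies within the scatter) and an at least 1.6-fold lower number from compound 2 to compound 4 (0.21 log units; that floor lies within the scatter). Both floors lie within the usual scatter, so the change from either aromatic ring group to iodo is not shown to exceed it. The other compounds remain limits, not numbers: the limit of > 20000 nM in this assay, at which 3 of the 4 values shown sit.

What the compounds shown leave open is whether bromo, chloro or an amine on this carbon would give a readable value. Also open, going by these compounds, is whether iodo keeps that value with dimethylamino in place of methyl.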